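Removing the Drawn Configuration on a Side-Chain Carbon

A few compounds are considered here, and "the series" means these few. Any claim that something is new, unique, unknown or untested is made for them only; others in the source may bear on it.

Measured compounds:
- Compound 1, `CN1CCN(CCCCCn2c3c(c4ccccc42)C(=O)c2c[n+]([O-])c4ccccc4c2C3=O)CC1`: 870 nM
- Compound 2, `O=C1c2c[n+]([O-])c3ccccc3c2C(=O)c2c1c1ccccc1n2Cc1cn(C[C@@H](O)CO)nn1`: 390 nM
- Compound 3, `CC1(C)O[C@@H](CO)[C@H](Cn2cc(Cn3c4c(c5ccccc53)C(=O)c3c[n+]([O-])c5ccccc5c3C4=O)nn2)O1`: 370 nM

All three compounds share one core and differ only in the group carried on the saturated chain carbon bound to an aromatic nitrogen. In a functional assay on A549 cells (Homo sapiens) for cytotoxicity, read by MTT assay, with a stated time of 72 h (a higher number here means a weaker inhibitor, a lower number a stronger inhibitor), compound 1 gives 870 nM. Replacing its side chain with the triazole-bearing chain gives compound 2, a step of a 2.2-fold lower number from compound 1 to compound 2 (0.35 log units; beyond the scatter). Compound 3 follows with a 1.1-fold lower number from compound 2 to compound 3 (0.02 log units; within the scatter), so compounds 2 and 3 sit alike, while compound 1 stands apart with the highest number.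

Compound 4, `O=C1c2c[n+]([O-])c3ccccc3c2C(=O)c2c1c1ccccc1n2Cc1cn(CC(O)CO)nn1`, is the next compound to be measured in this assay. Its relation to compound 2 is the two compounds have the same atoms and bonds; at least one stereo element is drawn with a configuration in one of them and without one in the other: 1 of 1 stereo elements differ; a stereocentre at a saturated chain carbon is drawn R in compound 2 and without a configuration in compound 4. Among the measured steps, only the pair of compounds 2 and 3 involves the chain near this stereocentre, and that step stayed within the scatter; no measured step tests a change of drawn configuration alone. Compound 4 is therefore expected to give a number close to that of compound 2, with a step of a 1.2-fold higher number from compound 2 to compound 4 (0.06 log units; within the scatter), not beyond the scatter. The estimate for compound 4 is 450 nM, with a range from 250 nM to 800 nM.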

Compound 4, half-maximal inhibitory concentration: 880 nM
For compound 4 the middle estimate is 2.0-fold (0.29 log units) below the measured one; measured number above the stated range.
By their numbers in this assay, from the lowest: compounds 3 and 2 (each within the scatter of the next); then compounds 1 and 4 (each within the scatter of the next).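

In this assay, a change in how one side-chain carbon is drawn comes with a 2.3-fold higher number from compound 2 to compound 4 (0.35 log units; beyond the scatter), and atoms and bonds stay the same, so the only structural difference on record is this: the fact that one of compounds 2 and 4 is drawn with a defined configuration and the other without, at the place where they differ

The triazole chain's edge over the methylpiperazine chain therefore depends on which drawing is compared, since a 1.0-fold higher number from compound 1 to compound 4 (0.00 log units; within the scatter) sits against the earlier 2.2-fold lower number from compound 1 to compound 2 (0.35 log units; beyond the scatter). Likewise, 1,2-dihydroxyethyl in place of the dioxolane group now gives a 2.4-fold higher number from compound 3 to compound 4 (0.38 log units; beyond the scatter), although compounds 2 and 3 sat alike.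

The compounds shown leave open what the undrawn configuration of compound 4 stands for, and how a side chain drawn S would behave. They also leave open how the triazole chain would fare with an amine or a carboxylic acid in place of the diol.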